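A one-carbon ester change from a limit value

This account rests on a few compounds, and the source may have more. Where it says the series, first, only, none or still open, it means among the compounds named here.

In a functional assay on the whole organism with Rattus norvegicus as the target (on this read-out lower numbers stand for an effect already at smaller amounts and higher numbers for an effect only at larger amounts of compound), compound 1 `CCOC(=O)C(=O)Nc1nc(-c2ccc(N(C)C)cc2)cs1` gives about 1 mg/kg, a measured number. Compound 2 `CCOC(=O)c1ccc(-c2csc(NC(=O)C(=O)OC)n2)cc1` gives > 10 mg/kg in this assay, and this is a limit of the assay, not a number.

Compound 3 `CCOC(=O)C(=O)Nc1nc(-c2ccc(C(=O)OCC)cc2)cs1` keeps the structure of compound 2 apart from one place: methyl in place of hydrogen on a saturated chain carbon bound to an oxygen next to a carbonyl group. In other words, methoxycarbonyl becomes ethoxycarbonyl, or methoxy becomes ethoxy.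

For the measured compounds named here, no measured pair here shows what this change does. The expectation therefore rests on compound 2, whose > 10 mg/kg is a limit, and no step beyond the usual scatter is expected in this assay, with neither direction favoured. The expected change, a step that the limit leaves unreadable from compound 2 to compound 3, is accordingly small. For compound 3 the estimated value is 12 mg/kg, with an expected range from 4 mg/kg to 30 mg/kg.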

Compound 3, dose for half-maximal effect: > 10 mg/kg
Compound 3 ended at the assay's limit (the forecaster's own chance of this, stated with the estimate: 55%); the middle value is on the limit's open side.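

Compound 3 gives > 10 mg/kg in this assay, which is a limit of the assay and not a number. The change from methoxycarbonyl to ethoxycarbonyl cannot be read, because compound 2 and compound 3 both stop at the same limit: the limit of > 10 mg/kg in this assay, at which 2 of the 3 values shown sit. The new information comes from a different single change, ethoxycarbonyl in place of dimethylamino on an aromatic carbon, which gives an at least 10-fold higher number from compound 1 to compound 3 (1.00 log units; beyond the scatter), so this aromatic carbon clearly matters for the dose needed in the rat.

On these data alone, whether a carboxylic acid or a smaller amine on that aromatic carbon would give a measured number or stay at the limit remains open. As far as these compounds go, it also remains open whether a longer chain in place of the ethyl of the ethoxycarbonyl would bring any measurable effect.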